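The compounds below may be only part of what the source reports. "The series", "measured", "known", "first", "only" and "open" are said of these compounds alone.

In a functional assay on NCI-H522 cells (Homo sapiens) for inhibition, read by CellTiter-Glo, with a stated time of 48 h, in the presence of a further agent that is not named here (on this read-out higher numbers stand for weaker inhibition of growth and lower numbers for stronger inhibition of growth), compound 1 (`C#CCCCC(=O)Nc1ccc(C(=O)c2ccc(Nc3ncc(F)c(Nc4ccccc4NS(C)(=O)=O)n3)cc2)cc1`) gives 2700 nM, while compound 2 (`CS(=O)(=O)Nc1ccccc1Nc1nc(Nc2ccc(C(=O)OCc3ccccc3)cc2)ncc1F`) gives 40200 nM, the higher of the two numbers and beyond the scatter from compound 1. Compound 3 (`CS(=O)(=O)Nc1ccccc1Nc1nc(Nc2ccc(Oc3ccccc3)cc2)ncc1F`) carries phenoxy in place of benzyloxycarbonyl on an aromatic carbon. Among the measured compounds shown here, no measured pair isolates this change, so in this assay no step beyond the scatter is expected, with only a slight lean towards a lower number. The estimated step is a 1.6-fold lower number from compound 2 to compound 3 (0.21 log units; within the scatter). For compound 3 the expected value is 25000 nM, with an estimated range of 8000 nM to 60000 nM.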

Compound 3, concentration for 50% growth inhibition: 8300 nM
Beside the measured number, compound 3's estimate is 3.0-fold (0.48 log units) above it, within the range that was stated.
By their numbers in this assay, from the lowest: compound 1; then compound 3; then compound 2.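

In this assay, among the compounds shown here, the group on this aromatic carbon, para to a large group, clearly matters: phenoxy in place of benzyloxycarbonyl gives a 4.8-fold lower number from compound 2 to compound 3 (0.69 log units; beyond the scatter), the first single-place comparison in this set. Both groups carry one six-membered aromatic ring of carbon only, so the step comes with a change in what links that ring. Nothing measured here accounts for the step. The compounds shown do not separate the part played by the linking atoms from that of the ring itself. On these data alone, how an amine or a carboxylic acid on this carbon would read also remains open.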